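The source may report more compounds than this note shows. Statements on the series, on what has been measured and on what is new or still open speak of the compounds shown alone.

In a functional assay on MDA-MB-231 cells (Homo sapiens) for inhibition, read by MTT assay, with a stated time of 72 h (a lower number here means a stronger inhibitor, a higher number a weaker inhibitor), compound 1 (`Cc1ccc(-c2cc(C(=O)N3CCC4(CC3)CC(=O)c3nn(C(C)(C)C)cc3O4)c3ccccc3n2)cc1`) gives > 10000 nM, which is a limit of the assay. Compound 2 (`Cc1ccccc1-c1cc(C(=O)N2CCC3(CC2)CC(=O)c2nn(C(C)(C)C)cc2O3)c2ccccc2n1`) also gives only a limit, > 10000 nM. Compound 3 (`CC(C)(C)n1cc2c(n1)C(=O)CC1(CCN(C(=O)c3cc(-c4ccc(F)cc4)nc4ccccc34)CC1)O2`) likewise stands at a limit, > 10000 nM, so no number fixes its place. Going by the values given here, the series so far shows (the limit of > 10000 nM in this assay, at which 3 of the 3 values shown sit). Compound 4 (`CC(C)(C)n1cc2c(n1)C(=O)CC1(CCN(C(=O)c3cc(-c4ccc(Br)cc4)nc4ccccc34)CC1)O2`) has bromo in place of fluoro on an aromatic carbon, para to a large group: bromo in place of fluoro on an aromatic carbon. The measured changes, a step that the two limits leave unreadable from compound 1 to compound 3, a step that the two limits leave unreadable from compound 1 to compound 2 and a step that the two limits leave unreadable from compound 2 to compound 3, have no readable size and give no direction. No change beyond the scatter is therefore expected, and the expected step is a step that the limit leaves unreadable from compound 3 to compound 4. The estimate for compound 4 is 12000 nM, with an expected range of 5000 nM to 30000 nM.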

Compound 4, half-maximal inhibitory concentration: > 10000 nM
Compound 4: no number, only a limit; the forecaster's own chance of this, stated with the estimate: 85%; the middle value lies beyond the limit too.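

Compound 4 gives > 10000 nM in this assay, again a limit, so its steps from compound 1, compound 2 and compound 3 cannot be read. The compounds shown leave open how strongly any of them inhibits and whether these changes matter at all: the limit of > 10000 nM in this assay, at which 4 of the 4 values shown sit.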